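Phenyl for 3,4-difluorophenyl on the indoline-type aryl sulfonamide core

This account rests on a few compounds, and the source may have more. Where it says the series, first, only, none or still open, it means among the compounds named here.

Measured compounds:
compound 1 `COc1ccc(S(=O)(=O)N2CCc3cccc(-c4c(F)c(F)c(F)c(F)c4F)c32)cc1`: 4040 nM
compound 2 `COc1ccc(S(=O)(=O)N2CCc3cccc(-c4ccc(F)c(F)c4)c32)cc1`: 45 nM
compound 3 `COc1ccc(S(=O)(=O)N2CCc3cccc(-c4cc(OC)c(OC)c(OC)c4)c32)cc1`: 3690 nM

In a functional assay on KB cells (Homo sapiens) for inhibition, with a stated time of 72 h (a lower number here means a stronger inhibitor, a higher number a weaker inhibitor), compound 2 gives 45 nM, the lowest of the three numbers and the strongest inhibitor of the set: the gaps to compound 3, with 3690 nM, and to compound 1, with 4040 nM, both lie well beyond the scatter. Compounds 1 and 3 sit close to each other at the weak end of this assay.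

Compound 4 `COc1ccc(S(=O)(=O)N2CCc3cccc(-c4ccccc4)c32)cc1` has not been measured. It differs from compound 2 in one place, the aryl group carried on the shared core: phenyl in place of 3,4-difluorophenyl on an aromatic carbon.

For the measured compounds named here, no step between two measured compounds shows what removing the two fluorines alone does. The two measured neighbours of compound 2 carry much heavier substitution on that ring and are far weaker, which suggests that the pattern on this ring matters a great deal, but neither tells how a bare phenyl behaves. The expected step from compound 2 to compound 4 is a moderate loss, a 3.6-fold higher number from compound 2 to compound 4 (0.55 log units; beyond the scatter), going beyond the scatter but far short of the drop seen for compounds 1 and 3. In this assay compound 4 is therefore estimated at 160 nM, in the range 40 nM to 700 nM.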

Compound 4, half-maximal inhibitory concentration: 120 nM
Beside the measured number, compound 4's estimate is 1.3-fold (0.12 log units) above it, and the stated range covers the measured number.
By their numbers in this assay, from the lowest: compound 2; then compound 4; then compounds 3 and 1 (each within the scatter of the next).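

Removing both fluorines costs only a modest amount in this assay (a 2.7-fold higher number from compound 2 to compound 4 (0.43 log units; beyond the scatter)), so the bare phenyl ring already accounts for most of the activity seen with this aryl group on the shared core. For the compounds shown here, this also gives the series an unsubstituted reference point, which the earlier compounds lacked. Against it, substitution on this ring can be seen to work in either direction: compound 4 gives 120 nM, the 3,4-difluorophenyl ring of compound 2 gives a lower number, and the more heavily substituted rings give much higher numbers, with compound 3 at 3690 nM and compound 1 at 4040 nM.

The compounds shown leave open whether one fluorine alone would match the pair in compound 2, and how a chlorine, a single methoxy group, a hydroxyl or an amine on this phenyl ring would behave, or a pyridine ring in its place. Nothing available here accounts for the size of the step, so the role of the fluorines remains unexplained.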